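This account rests on a few compounds, and the source may have more. Where it says the series, first, only, none or still open, it means among the compounds named here.

Measured compounds:
compound 1, `COc1cc(-c2cc(/C=C/C(=O)c3ccc(N)cc3)[nH]n2)cc(OC)c1OC`, 2000 nM
compound 2, `COc1ccc(-c2cc(/C=C/C(=O)c3ccc(N)cc3)[nH]n2)cc1OC`, 2200 nM
compound 3, `COc1cc(C(=O)/C=C/c2cc(-c3cc(OC)c(OC)c(OC)c3)n[nH]2)cc(OC)c1OC`, 700 nM

All three were tested in a functional assay on MDA-MB-231 cells (Homo sapiens) for inhibition, read by MTT assay, with a stated time of 48 h; on this read-out higher numbers stand for weaker inhibition and lower numbers for stronger inhibition. Compound 1 gives 2000 nM, and compound 2 gives 2200 nM, so the two values lie within the usual scatter of each other. Compound 3 gives the lowest number of the three, 700 nM, and both other values sit beyond the scatter from it. The difference between the core of compound 3 and the core of compound 1 is not broken down here.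

Going from compound 1 to compound 2 the change is hydrogen in place of methoxy on an aromatic carbon. The step it made in this assay was a 1.1-fold higher number from compound 1 to compound 2 (0.04 log units; within the scatter).

Compound 4, `COc1ccc(-c2cc(/C=C/C(=O)c3cc(OC)c(OC)c(OC)c3)[nH]n2)cc1OC`, has not yet been measured. It differs from compound 3 by hydrogen in place of methoxy on an aromatic carbon, the same change as from compound 1 to compound 2, with the same surroundings at the place of the change. Going by the values given here, on the single earlier example, removing this methoxy group left the number essentially unchanged, so compound 4 is expected to stay close to compound 3, with an expected step of a 1.1-fold higher number from compound 3 to compound 4 (0.06 log units; within the scatter). The expectation rests on compound 1 to compound 2 showing a 1.1-fold higher number from compound 1 to compound 2 (0.04 log units; within the scatter), and on compound 3 giving 700 nM as the starting point. The estimate for compound 4 in this assay is therefore 800 nM, expected to fall between 350 nM and 1800 nM.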

Compound 4, half-maximal inhibitory concentration: 2000 nM
Compound 4: the middle estimate sits 2.5-fold (0.40 log units) below what was measured, outside the stated range (above it).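

In this assay, putting hydrogen in place of methoxy on the core of compound 3 gave a 2.9-fold higher number from compound 3 to compound 4 (0.46 log units; beyond the scatter), so on this core the loss of the methoxy group shows up as a real step, which is weaker inhibition in these cells. Set beside the earlier example, where the same change stayed within the scatter, the new step looks larger, yet the two steps cannot be told apart: the same change on two cores in this assay, a 1.1-fold higher number (0.04 log units; within the scatter) from compound 1 to compound 2 and a 2.9-fold higher number (0.46 log units; beyond the scatter) from compound 3 to compound 4, 2.6-fold (0.41 log units) apart, within the scatter of two such steps. Going by these compounds alone, this shows that a single step within the scatter on one core was a poor guide to the size of the step on the other, but it does not show that the two cores truly respond differently, and with only two pairs no rule for carrying this change across the series can be drawn in either direction.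

The compounds shown leave open how other groups would behave at this place on the ring, such as a hydroxyl group, a chlorine atom or the longer ethoxy chain in place of methoxy. They also leave open whether further matched pairs on these two cores would bring the steps closer together or pull them further apart.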